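A few compounds are considered here, and "the series" means these few. Any claim that something is new, unique, unknown or untested is made for them only; others in the source may bear on it.

Compound 1 `CCCCCC(=O)c1c(O)c(Cl)c(OC)c(Cl)c1O`, compound 2 `CCCCCC(=O)c1c(O)c(Cl)c(O)c(Cl)c1O` and compound 3 `CCCCCC(=O)c1c(O)c(Cl)c(C)c(Cl)c1O` share one core and differ in a single ring substituent. In a functional assay on the whole organism (S2 cells, strain S2) for inhibition, with Drosophila as the target, read by a luciferase reporter, with stated times of 1.5 h and 8 h (on this read-out higher numbers stand for weaker inhibition and lower numbers for stronger inhibition), compound 1 gives 4600 nM, compound 2 gives 9900 nM and compound 3 gives 3800 nM. Compound 2 thus carries the highest number of the three, set apart from both others by a 2.2-fold higher number from compound 1 to compound 2 (0.33 log units; beyond the scatter) and by a 2.6-fold lower number from compound 2 to compound 3 (0.42 log units; beyond the scatter), whereas a 1.2-fold lower number from compound 1 to compound 3 (0.08 log units; within the scatter) lies within the scatter. Compound 4 `CCCCCCCC(=O)c1c(O)c(Cl)c(O)c(Cl)c1O` departs from compound 2 on the chain instead: ethyl in place of hydrogen on a saturated chain carbon, five bonds along the chain from a carbonyl carbon. Among the compounds with values here, none of the measured steps touches the saturated chain, so no step bears on this change, and no shift beyond the scatter is expected in this assay in either direction. Compound 4 is therefore expected near 8000 nM, within 2500 nM to 25000 nM. The expected step is a 1.2-fold lower number from compound 2 to compound 4 (0.09 log units; within the scatter).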

Compound 4, half-maximal inhibitory concentration: 3700 nM
Beside the measured number, compound 4's estimate is 2.2-fold (0.33 log units) above it, and the stated range covers the measured number.
By their numbers in this assay, from the lowest: compounds 4, 3 and 1 (each within the scatter of the next); then compound 2.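

Ethyl in place of hydrogen on a saturated chain carbon, five bonds along the chain from a carbonyl carbon, gives a 2.7-fold lower number from compound 2 to compound 4 (0.43 log units; beyond the scatter) in this assay. The saturated chain is thus a second place where the number responds, which the ring-substituent steps could not show, and this modest step runs towards stronger inhibition. No measurement at hand accounts for the shift.

As far as these compounds go, whether a longer chain continues this shift, or a carboxylic acid on the chain reverses it, remains open. Also open, from the compounds shown here alone, is whether the same chain change holds with the methoxy of compound 1 or the methyl of compound 3 on the ring.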